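Cytotoxicity notes on the chlorophenoxy-pentyl thiourea series

A few compounds are considered here, and "the series" means these few. Any claim that something is new, unique, unknown or untested is made for them only; others in the source may bear on it.

Three compounds have been run in an ADME assay on Huh-7 cells (Homo sapiens) for cytotoxicity; a lower number here means that less compound is tolerated, a higher number that more compound is tolerated. Compound 1 `NC(=S)N1CCCc2c(OCCCCCOc3cccc4ccccc34)cccc21` gives > 50000 nM, which is a limit of the assay and not a number. Compound 2 `O=C(NC(=S)n1ccc2c(OCCCCCOc3ccc(Cl)cc3)cccc21)c1ccccc1` gives 29500 nM. Compound 3 `N#Cc1cccc(C(=O)NC(=S)N2CCc3c(OCCCCCOc4ccc(Cl)cc4)cccc32)c1` gives 9750 nM, the lowest of the two numbers; the nearest value, that of compound 2, lies above it by a gap beyond the usual scatter. The set also holds (the limit of > 50000 nM in this assay, at which 1 of the 3 values shown sits). Compound 4 `Cc1ccc(C(=O)NC(=S)N2CCc3c(OCCCCCOc4ccc(Cl)cc4)cccc32)cc1` is not yet measured and differs from compound 3 in one place: 4-methylphenyl in place of 3-cyanophenyl on a carbonyl carbon. For the measured compounds named here, no measured pair follows this change, so no direction can be drawn from the data. For compound 4 the expected step is a 1.2-fold lower number from compound 3 to compound 4 (0.09 log units; within the scatter), none beyond the scatter. For compound 4 the estimate in this assay is 8000 nM, with a range from 3000 nM to 25000 nM.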

Compound 4, half-maximal cytotoxic concentration: > 50000 nM
Compound 4: a limit, no number (the forecaster's own chance of this, stated with the estimate: 10%); at least 6.2-fold (0.79 log units) between middle value and limit.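

In this assay, for the compounds shown here, the first single-place change in this set gives an at least 5.1-fold higher number from compound 3 to compound 4 (0.70 log units; beyond the scatter), so the group on this carbonyl carbon bears on the read-out. The size of the step has only a floor, as compound 4 returns a limit and not a number: the limit of > 50000 nM in this assay, at which 2 of the 4 values shown sit.

From the compounds shown here alone, whether the step follows the loss of the nitrile or the arrival of the methyl stays open, since 3-cyanophenyl and 4-methylphenyl differ in both the group and its ring position. A 4-cyanophenyl or 3-methylphenyl group on this carbonyl would separate the two.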